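The source may report more compounds than this note shows. Statements on the series, on what has been measured and on what is new or still open speak of the compounds shown alone.

Compound 3 `O=S(=O)(c1ccc(C(F)(F)F)cc1)c1cc(F)c(O)c2ncccc12` gives 12 uL/min in an ADME assay on cells (Hepatocyte, Rattus norvegicus) for pharmacokinetics (on this read-out higher numbers stand for fast clearance and lower numbers for slow clearance), the lower of the two numbers reported so far. Compound 2 `O=S(=O)(c1ccc(O)c2ncccc12)N1CCC(c2ccc(F)cc2)C1` gives 255 uL/min, and the gap between compound 2 and compound 3 lies beyond the usual scatter. Compound 1 `O=S(=O)(c1ccc(O)c2ncccc12)C1CCCC1` has "not determined" (no result reported) in this assay. Compound 4 `O=S(=O)(c1ccc(F)cc1)c1cc(F)c(O)c2ncccc12` differs from compound 3 in one place: fluoro in place of trifluoromethyl on an aromatic carbon. For the measured compounds named here, with no step of this kind measured, the change is expected to move this assay little, toward a slightly lower number or none beyond the scatter. The estimate for compound 4 is 9 uL/min, within a range from 3 uL/min to 27 uL/min. The expected step of a 1.3-fold lower number from compound 3 to compound 4 (0.12 log units; within the scatter) lies within the usual scatter.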

Compound 4, intrinsic clearance in a liver preparation (reported as CLH), per the amount of preparation that the assay uses: 15 uL/min
Beside the measured number, compound 4's estimate is 1.7-fold (0.22 log units) below it; the range from low to high includes it.
By their numbers in this assay, from the lowest: compounds 3 and 4 (each within the scatter of the next); then compound 2.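

In this assay, putting fluoro in place of trifluoromethyl on an aromatic carbon, para to a large group, gives a 1.3-fold higher number from compound 3 to compound 4 (0.10 log units; within the scatter). For the compounds shown here, this is the first step read at this place, and it shows that the two groups cannot be told apart on this read-out, although one has far fewer heavy atoms than the other. Nothing at hand explains why the two groups read alike. The compounds shown leave open whether an amine, a carboxylic acid or a longer chain on this aromatic carbon would read the same way. On these data alone, whether this step carries over to another core also stays open.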